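The compounds below may be only part of what the source reports. "The series", "measured", "known", "first", "only" and "open" are said of these compounds alone.

Measured compounds and their results:
- compound 1 `Cc1nc(C)c(C(=O)Oc2ccccc2/C=C/C(=O)O)nc1C`, 64.9%
- compound 2 `COc1ccc(/C=C/C(=O)O)c(OC(=O)c2nc(C)c(C)nc2C)c1`, 31.6%
- compound 3 `COc1ccc(OC(=O)c2nc(C)c(C)nc2C)c(/C=C/C(=O)O)c1`, 62.9%

In a functional assay on EA.hy 926 cells (Homo sapiens) for cytotoxicity, read by MTT assay, with stated times of 24 h and 12 h, tested at 50 uM (a higher number here means a stronger effect of the compound at the concentration tested, a lower number a weaker effect), compound 3 holds the second highest of the three numbers. The gap to compound 1 is within the scatter, as a number 2 percentage points lower from compound 1 to compound 3 (within the scatter) shows, whereas compound 2 lies beyond the scatter below it. Compound 4 `CCOC(=O)/C=C/c1cc(OC)ccc1OC(=O)c1nc(C)c(C)nc1C` differs from compound 3 by one change: ethyl in place of hydrogen on an oxygen next to a carbonyl group. Neither measured step touches this position: a number 33.3 percentage points lower from compound 1 to compound 2 (beyond the scatter) and a number 2 percentage points lower from compound 1 to compound 3 (within the scatter) both concern methoxy in place of hydrogen on an aromatic carbon, and they disagree in size. No guidance therefore exists for the ester, and no step beyond the scatter is expected in this assay, so a number 2.9 percentage points lower from compound 3 to compound 4 (within the scatter) is the estimated change. Compound 4 is expected to give about 60%, within 35% to 80%.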

Compound 4, a percentage reported as activity, at one concentration (the size of the read-out at that concentration, not a potency): 27.8%
The estimate for compound 4 lay 32.2 percentage points above the measured number, and the stated range ends above it.
By their numbers in this assay, from the lowest: compounds 4 and 2 (each within the scatter of the next); then compounds 3 and 1 (each within the scatter of the next).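

Ethyl in place of hydrogen on the oxygen next to a carbonyl group gives, in this assay, a number 35.1 percentage points lower from compound 3 to compound 4 (beyond the scatter). This shows that the carboxy end of the 2-carboxyethenyl chain matters to this read-out, a position the earlier methoxy steps did not touch. No available measurement accounts for the drop.

On these data alone, whether a methyl ester, a longer chain on this oxygen or an amide would read as low as the ethoxycarbonyl group stays open. So does whether the same change would have a similar effect with the methoxy group placed as in compound 2.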